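Halogen swap on a pyridine-diazepane acetylcholine receptor ligand

The compounds below may be only part of what the source reports. "The series", "measured", "known", "first", "only" and "open" are said of these compounds alone.

The measured compounds are:
compound 1 `Clc1cncc(N2CCCNCCC2)c1` with 2 nM
compound 2 `COc1cncc(N2CCCNCC2)c1` with 1.91 nM
compound 3 `C/C=C\Oc1cncc(N2CCCNCC2)c1` with 1.29 nM

All three values come from an assay on HEK293 cells for displacement of a labelled ligand from Neuronal acetylcholine receptor; alpha4/beta2 (Homo sapiens); a lower number here means a stronger inhibitor, a higher number a weaker inhibitor. Compound 1, compound 2 and compound 3 lie within the scatter of one another, so none of them can be set above or below the others; compound 1 simply belongs to the same narrow band as the two others.

Compound 4 `Brc1cncc(N2CCCNCCC2)c1` is not yet measured. Its change from compound 1 is bromo in place of chloro on an aromatic carbon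

Within the data shown here, only one step is recorded among the measured compounds: a 1.5-fold lower number from compound 2 to compound 3 (0.17 log units; within the scatter). That step exchanges groups on an oxygen, not a halogen on the aromatic carbon, so it does not bear on the change from compound 1 to compound 4. What the data do show is that three different groups at this position on the shared core give values that cannot be told apart. Among the measured compounds shown here, with no step for chloro to bromo and no spread among the neighbours, the expectation for compound 4 is a change of no size beyond the scatter, no change at the digits printed from compound 1 to compound 4 (within the scatter).

Compound 4 is therefore estimated at 2 nM, within a range from 0.8 nM to 5 nM.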

Compound 4, half-maximal inhibitory concentration: 2.82 nM
Beside the measured number, compound 4's estimate is 1.4-fold (0.15 log units) below it; low and high end bracket the measured number.
By their numbers in this assay, from the lowest: compounds 3, 2, 1 and 4 (each within the scatter of the next, the first and the last beyond it).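

In this assay the halogen on the aromatic carbon of the shared core can now be read directly, and the exchange gives a 1.4-fold higher number from compound 1 to compound 4 (0.15 log units; within the scatter) for bromo in place of chloro, so the two halogens cannot be told apart here. The earlier step concerned groups on an oxygen and said nothing about a halogen, whereas this pair differs only at that one aromatic carbon, and neither chloro nor bromo brings a hydrogen-bond donor, a hydrogen-bond acceptor or a net charge. Nothing in the available data offers an explanation for this result.

The compounds shown leave open whether this aromatic carbon would accept quite different groups, such as an amine, a carboxylic acid or a longer alkyl chain, while staying in the same narrow band of values, and whether fluoro or iodo would also do so. They also leave open whether bromo in place of chloro would read the same way on the core of compound 2, since a single pair cannot show how far this result carries.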